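A few compounds are considered here, and "the series" means these few. Any claim that something is new, unique, unknown or untested is made for them only; others in the source may bear on it.

Compound 2 `Nc1ccccc1C(=O)N/N=C/c1ccc2no[n+]([O-])c2c1` sits highest of the three numbers in a physicochemical assay for lipophilicity, read by HPLC, measured as octanol-water partition; a lower number here means a more polar compound, a higher number a more lipophilic compound; compound 1 `O=C(N/N=C/c1ccc2no[n+]([O-])c2c1)c1ccccc1O` gives 1.3, compound 2 gives 2, and compound 3 `N#Cc1c(-c2ccccc2)[n+]([O-])c2ccc(/C=N/NC(=O)c3ccncc3)cc2[n+]1[O-]` gives 1. The step of a number 0.70 log units higher from compound 1 to compound 2 (beyond the scatter) is the only one between two of these compounds that differ in one place. Compound 4 `O=C(N/N=C/c1ccc2no[n+]([O-])c2c1)c1ccc(O)cc1` differs from compound 2 by 4-hydroxyphenyl in place of 2-aminophenyl on a carbonyl carbon. Among the compounds with values here, the step from compound 1 to compound 2 bears on this change, since it reverses the hydroxy-for-amino swap, but the hydroxy group of compound 4 also sits elsewhere on the ring, and no measured pair covers that. In this assay the expected step is a number 0.80 log units lower from compound 2 to compound 4 (beyond the scatter), downward and beyond the scatter. Compound 4 is estimated at 1.2, within 0.7 to 1.7.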

Compound 4, partition coefficient: 1.2
Estimate against measurement, compound 4: no gap at the digits printed, within the range that was stated.
By their numbers in this assay, from the lowest: compounds 3, 4 and 1 (each within the scatter of the next); then compound 2.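

In this assay, 4-hydroxyphenyl in place of 2-aminophenyl on the carbonyl carbon gives a number 0.80 log units lower from compound 2 to compound 4 (beyond the scatter), a second change at this position that ends beyond the scatter of compound 2. 4-hydroxyphenyl in place of 2-hydroxyphenyl gives a number 0.10 log units lower from compound 1 to compound 4 (within the scatter), so the two hydroxyphenyl groups cannot be told apart in this assay. Compound 2 therefore stands apart from both hydroxyphenyl compounds. From the compounds shown here alone, how a methoxyphenyl or a carboxyphenyl group would read on the same carbonyl carbon stays open. No measured evidence on hand gives a cause for either step.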